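Swapping an aryl group on a kynurenine 3-monooxygenase inhibitor

The source may report more compounds than this note shows. Statements on the series, on what has been measured and on what is new or still open speak of the compounds shown alone.

Of the compounds shown here, two have been tested so far. Compound 1, with the structure `Cc1ccc(S(=O)(=O)Nc2nc(-c3ccc(Cl)c(Cl)c3)cs2)cc1`, gives 56 nM in an assay on isolated protein for inhibition of kynurenine 3-monooxygenase (Rattus norvegicus); on this read-out lower numbers stand for stronger inhibition and higher numbers for weaker inhibition. Compound 2, with the structure `O=C(O)c1cc(-c2cccc([N+](=O)[O-])c2)on1`, gives 2680 nM in this assay. Compound 1 therefore has the lower of the two numbers, and its gap to compound 2 lies well beyond the usual scatter of this measurement, so compound 1 is the stronger inhibitor of this pair.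

Compound 3, with the structure `Cc1ccc(S(=O)(=O)Nc2nc(-c3ccc(O)c(C)c3)cs2)cc1`, has not yet been measured. Within the data shown here, its core is the same as that of compound 1, and the only change is 4-hydroxy-3-methylphenyl in place of 3,4-dichlorophenyl on an aromatic carbon. Among the measured compounds shown here, no measured pair shows what such a swap does here, so the expectation rests on the general size of steps seen so far. A moderate weakening is expected, with a step of an 8.9-fold higher number from compound 1 to compound 3 (0.95 log units; beyond the scatter). Compound 3 is thus estimated at 500 nM, in a range from 100 nM to 3000 nM.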

Compound 3, half-maximal inhibitory concentration: 114 nM
Compound 3: middle estimate off by 4.4-fold (0.64 log units), on the high side, within the range that was stated.
By their numbers in this assay, from the lowest: compound 1; then compound 3; then compound 2.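

In this assay the swap of 3,4-dichlorophenyl for 4-hydroxy-3-methylphenyl on the shared core gives a 2.0-fold higher number from compound 1 to compound 3 (0.31 log units; beyond the scatter) and counts as a modest step. At this position, then, the chlorine atoms can be replaced by a methyl and a hydroxyl group at only a small cost in inhibition, with the count of heavy atoms unchanged. Among these compounds, nothing measured so far accounts for the size of this step.

This single pair cannot separate the parts of the change. From the compounds shown here alone, how much of the step goes with losing the chlorine atoms, adding the methyl or adding the hydroxyl remains unknown. The compounds shown also leave open how an unsubstituted phenyl, a methoxy-bearing phenyl or an amine-bearing phenyl would compare at this position.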